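The source may hold more compounds than are shown below. What is called first, only, known or untested is meant among the compounds shown, and "the series" means these compounds.

Measured in an ADME assay on microsomes from liver (Rattus norvegicus) for metabolic stability, read by mass spectrometry, using NADPH, with a stated time of 10 min; a higher number here means that more of the compound is left, a lower number that less of the compound is left:
- compound 1 `COc1cccc(OC)c1-c1c(C2CC2)[nH]c(=O)c(-c2nnc(Cc3ccc(Cl)cc3)o2)c1O`: 51%
- compound 2 `CCOCc1[nH]c(=O)c(-c2nnc(Cc3ccc(Cl)cc3)o2)c(O)c1-c1c(OC)cccc1OC`: 74%

Compound 1 is the lower of the two. Compound 3 `CCCCc1[nH]c(=O)c(-c2nnc(Cc3ccc(Cl)cc3)o2)c(O)c1-c1c(OC)cccc1OC` differs from it as follows: butyl in place of cyclopropyl on an aromatic carbon. Among the measured compounds shown here, only one measured step bears on this change: a number 23 percentage points higher from compound 1 to compound 2 (beyond the scatter), a modest rise beyond the scatter on replacing the same cyclopropyl with ethoxymethyl. For the measured compounds named here, no butyl compound has been measured, so this step is only a loose guide, and no shift beyond the scatter is expected. The expected change is a number 1 percentage points lower from compound 1 to compound 3 (within the scatter). For compound 3 the estimate is 50%, with an expected range of 30% to 70%.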

Compound 3, percent of the compound remaining in the Rattus norvegicus assay: 22%
Beside the measured number, compound 3's estimate is 28 percentage points above it, outside the stated range (below it).
By their numbers in the Rattus norvegicus assay, from the lowest: compound 3; then compound 1; then compound 2.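

In the Rattus norvegicus assay butyl gives a number 29 percentage points lower from compound 1 to compound 3 (beyond the scatter) and, set against ethoxymethyl, a number 52 percentage points lower from compound 2 to compound 3 (beyond the scatter) so the rise seen with ethoxymethyl does not extend to every open chain at this position. The same change from cyclopropyl to butyl also separates the two compounds in a physicochemical assay for solubility, in phosphate buffer, with a stated time of 24 h, at pH 7.4 (a lower number here means a less soluble compound, a higher number a more soluble compound), as follows: the measured solubility of compound 1, 12 ug/mL, and of compound 3, < 1 ug/mL, an at least 12-fold lower number (1.07 log units; beyond the scatter). In the physicochemical assay compound 1 gives 12 ug/mL. For compound 3 the value < 1 ug/mL is a limit of the assay, not a number.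

On these data alone, whether the fall in the Rattus norvegicus assay tracks the butyl chain as a whole or the absence of the ether oxygen stays open, as does the reading with a shorter alkyl chain, an amine or a carboxylic acid at this position.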